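The source may hold more compounds than are shown below. What is called first, only, known or untested is meant among the compounds shown, and "the series" means these compounds.

Measured compounds in a functional assay on UACC-257 cells (Homo sapiens) for inhibition, read by sulforhodamine B assay, with a stated time of 48 h, tested at 10 uM; a higher number here means a weaker effect of the compound at the concentration tested, a lower number a stronger effect:
- compound 1, `COc1cc2cc(Oc3ccc(NC(=O)Nc4ccccc4)cc3)c(C)nc2cc1OC`: compound 1 gives 92.4%
- compound 2, `COc1cc2cc(Oc3ccc(NC(=O)Nc4ccc(C)cc4)cc3)c(C)nc2cc1OC`: compound 2 gives 112%
- compound 3, `COc1cc2cc(Oc3ccc(NC(=O)Nc4cccc(C(F)(F)F)c4)cc3)c(C)nc2cc1OC`: compound 3 gives -14.5%

Compound 3 stands lowest of the three numbers in this assay, beyond the scatter from both others: the step of a number 106.9 percentage points lower from compound 1 to compound 3 (beyond the scatter) and the step of a number 126.5 percentage points lower from compound 2 to compound 3 (beyond the scatter) are both large, whereas the step of a number 19.6 percentage points higher from compound 1 to compound 2 (beyond the scatter) is modest and runs the other way.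

Compound 4, `COc1cc2cc(Oc3ccc(NC(=O)Nc4ccc(Cl)c(C(F)(F)F)c4)cc3)c(C)nc2cc1OC`, differs from compound 3 by chloro in place of hydrogen on an aromatic carbon. Within the data shown here, no measured step covers a chloro entering at this place. Among the measured compounds shown here, the only steps at hand concern groups entering the same ring in compound 1: methyl gave a number 19.6 percentage points higher from compound 1 to compound 2 (beyond the scatter), trifluoromethyl gave a number 106.9 percentage points lower from compound 1 to compound 3 (beyond the scatter). Compound 3 already reads near the bottom of the scale in this assay, so little room remains downward, and a further substituent on the same ring is not expected to undo the large effect seen. The expected step of a number 4.5 percentage points higher from compound 3 to compound 4 (within the scatter) is therefore none beyond the scatter. Compound 4 is estimated at -10%, with a range from -35% to 25%.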

Compound 4, a percentage reported as activity, at one concentration (the size of the read-out at that concentration, not a potency): -12.5%
Beside the measured number, compound 4's estimate is 2.5 percentage points above it; the range from low to high includes it.
By their numbers in this assay, from the lowest: compounds 3 and 4 (each within the scatter of the next); then compound 1; then compound 2.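

Chloro on the aromatic carbon ortho to a trifluoromethyl group and para to a large group leaves the reading in this assay unchanged within the scatter (a number 2 percentage points higher from compound 3 to compound 4 (within the scatter)), so this position takes a chloro with the large effect of compound 3 intact. The large effect also persists against the compounds without trifluoromethyl (a number 104.9 percentage points lower from compound 1 to compound 4 (beyond the scatter); a number 124.5 percentage points lower from compound 2 to compound 4 (beyond the scatter)), and so far both compounds with a trifluoromethyl group read low, with none going against this. No measurement on hand explains these readings.

On these data alone, whether a 4-chlorophenyl group without trifluoromethyl carries any of the effect remains open, as does whether a morpholine or a carboxylic acid at this place would keep it. Readings at a single concentration also leave open whether the effects of compound 3 and compound 4 would differ at any other concentration.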